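Amide-nitrogen aryl swap on the shared core

This account rests on a few compounds, and the source may have more. Where it says the series, first, only, none or still open, it means among the compounds named here.

Of the compounds shown here, two of the shared core have numbers so far. Compound 1 `CO[C@@H]1CC=C2NN(c3ccc(C)cc3)C(=O)C[C@]2(C)O1` gives 25300 nM in a functional assay on SK-N-SH cells (Homo sapiens) for inhibition, read by sulforhodamine B assay, with a stated time of 48 h; on this read-out higher numbers stand for weaker inhibition and lower numbers for stronger inhibition. Compound 2 `CO[C@@H]1CC=C2NN(c3cc4ccccc4[nH]3)C(=O)C[C@]2(c2ccncc2)O1` gives 3900 nM in this assay, the lowest of the two numbers; compound 1 is its nearest neighbour and stands beyond the scatter. Compound 3 `CO[C@@H]1CC=C2NN(c3ccc(C)cc3)C(=O)C[C@]2(c2ccncc2)O1` differs from compound 2 in one place: 4-methylphenyl in place of 1H-indol-2-yl on an amide-type nitrogen in a ring. Going by the values given here, no measured pair shows this change alone, so its size is not known. A weakening step a 2.6-fold higher number from compound 2 to compound 3 (0.41 log units; beyond the scatter) is expected because compound 1 with its 4-methylphenyl gives 25300 nM. Compound 3 is estimated at 10000 nM, range 3000 nM to 40000 nM.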

Compound 3, half-maximal inhibitory concentration: 8100 nM
For compound 3 the middle estimate is 1.2-fold (0.09 log units) above the measured one, and the stated range covers the measured number.
By their numbers in this assay, from the lowest: compound 2; then compound 3; then compound 1.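

In this assay the amide-type nitrogen in a ring now has a measured single change: 4-methylphenyl in place of 1H-indol-2-yl gives a 2.1-fold higher number from compound 2 to compound 3 (0.32 log units; beyond the scatter) on its own. The saturated ring carbon also has one, as pyridin-4-yl in place of methyl gives a 3.1-fold lower number from compound 1 to compound 3 (0.49 log units; beyond the scatter) with the 4-methylphenyl held fixed. Both places therefore move the number, each beyond the scatter.

Still open, going by these compounds, is whether an aminophenyl on that nitrogen, or an ethyl or a carboxylic acid on that carbon, would shift the number further. Nothing available bears on why either step arises.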